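Ethyl to Isopropyl on Two Related Cores

A few compounds are considered here, and "the series" means these few. Any claim that something is new, unique, unknown or untested is made for them only; others in the source may bear on it.

Measured so far in an ADME assay on the whole organism with Oryza sativa as the target, tested at 10 uM; a higher number here means a weaker effect of the compound at the concentration tested, a lower number a stronger effect:
compound 1, `CCc1cccc(NC(=O)N[C@H](C)c2ccccc2)c1`, gives 36%
compound 2, `CCc1ccc(NC(=O)N[C@H](C)c2ccccc2)cc1`, gives 44%
compound 3, `CC(C)c1cccc(NC(=O)N[C@H](C)c2ccccc2)c1`, gives 44%

Compound 1 and compound 3 share one core; compound 2 and the not yet measured compound 4, `CC(C)c1ccc(NC(=O)N[C@H](C)c2ccccc2)cc1`, share another. The difference between the two cores is not broken down here. In this assay compound 2 and compound 3 stand level at the digits shown, and compound 1 lies within the scatter of both, so no ordering among the three can be read.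

The change from compound 1 to compound 3 is methyl in place of hydrogen on a saturated chain carbon bound to an aromatic carbon and a saturated chain carbon, and in this assay it made a number 8 percentage points higher from compound 1 to compound 3 (within the scatter). The change from compound 2 to compound 4 is methyl in place of hydrogen on a saturated chain carbon bound to an aromatic carbon and a saturated chain carbon, the same change on the other core. Because a number 8 percentage points higher from compound 1 to compound 3 (within the scatter) stayed within the scatter, a similarly small step is expected here, a number 4 percentage points higher from compound 2 to compound 4 (within the scatter). For compound 4 the expected read-out in this assay is therefore 48%, with a likely range from 34% to 62%.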

Compound 4, a percentage reported as activity, at one concentration (the size of the read-out at that concentration, not a potency): 49%
Compound 4: the middle estimate sits 1 percentage points below what was measured, within the range that was stated.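

In this assay, putting isopropyl in place of ethyl on the core of compound 2 gave a number 5 percentage points higher from compound 2 to compound 4 (within the scatter). Set beside the earlier step, the change reads alike on both cores: the same change on two cores in this assay, a number 8 percentage points higher (within the scatter) from compound 1 to compound 3 and a number 5 percentage points higher (within the scatter) from compound 2 to compound 4, 3 percentage points apart, within the scatter of two such steps. Within the data shown here, this agreement shows only that the step stayed small on both cores; it does not show that the change has any real effect, since each step lies within the scatter, and two cores are too few to predict what it would do on a third.

The compounds shown carry only ethyl or isopropyl at this place, which leaves open how a longer chain such as butyl, a cyclopropyl ring, an amine or a carboxylic acid would read in this assay. They also leave open whether a change larger than one added methyl would produce a step beyond the scatter, and whether such a step would then carry from one core to the other as this small one appears to do.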